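The source may hold more compounds than are shown below. What is called first, only, known or untested is meant among the compounds shown, and "the series" means these compounds.

Measured so far:
compound 1 `Nc1cc(N)c2nc(-c3ccccc3)c(NCc3ccc(Cl)c(Cl)c3)nc2c1` — 32400 nM
compound 2 `CCOC(=O)[C@H](CCC(=O)O)NC(=O)c1ccc(Sc2nc3cc(N)cc(N)c3nc2-c2ccccc2)cc1` — < 100000 nM
compound 3 `CCOC(=O)[C@H](CCC(=O)O)NC(=O)c1ccc(Oc2nc3cc(N)cc(N)c3nc2-c2ccccc2)cc1` — 14800 nM

In a functional assay on A498 cells (Homo sapiens) for inhibition, read by sulforhodamine B assay, with a stated time of 48 h (on this read-out higher numbers stand for weaker inhibition of growth and lower numbers for stronger inhibition of growth), compound 1 gives 32400 nM, the higher of the two numbers in hand. Compound 3 gives 14800 nM in this assay, a lower number, and that gap lies beyond the scatter. For compound 2 this assay reports only a limit, < 100000 nM, which is the limit of < 100000 nM in this assay, at which 1 of the 3 values shown sits, and not a number. Among the measured compounds shown here, no pair among the three differs in a single place, so no measured step is available to calibrate the change to the next compound.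

Compound 4 `COc1ccc(CNc2nc3cc(N)cc(N)c3nc2-c2ccccc2)cc1` is to be measured in this assay. It differs from compound 1 as follows: 4-methoxyphenyl in place of 3,4-dichlorophenyl on a saturated chain carbon bound to a nitrogen on an aromatic ring. The shared core and the rest of the molecule stay as in compound 1. With no measured step of this kind in the set, the expectation is a step of modest size or none beyond the scatter, and if anything toward a higher number. The step from compound 1 to compound 4 is estimated as a 1.4-fold higher number from compound 1 to compound 4 (0.14 log units; within the scatter). For compound 4 in this assay the estimate is 45000 nM, with the range expected to run from 15000 nM to 100000 nM.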

Compound 4, concentration for total growth inhibition: < 100000 nM
Compound 4: a limit, no number; the forecaster's own chance of this, stated with the estimate: 30%; the middle value lies beyond the limit too.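

Compound 4 gives < 100000 nM in this assay, a limit and not a number, so the step from compound 1 to compound 4 cannot be read. The compounds shown leave open how far 4-methoxyphenyl in place of 3,4-dichlorophenyl shifts growth inhibition, or in which direction.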